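Adding a Nitro Group to Compound 2

The source may hold more compounds than are shown below. What is called first, only, known or untested is meant among the compounds shown, and "the series" means these compounds.

Of the compounds shown here, three sharing one core have been measured in a functional assay on WIL2-NS cells (Homo sapiens) for cytotoxicity, read by MTT assay, with a stated time of 96 h; on this read-out higher numbers stand for an effect only at larger amounts of compound and lower numbers for an effect already at smaller amounts. Compound 1 `O=C(/C(=C\c1c(-c2ccccc2)[nH]c2ccccc12)C(=O)C(F)(F)F)c1ccco1` gives 2300 nM. Compound 3 `N#C/C(=C\c1c(-c2ccccc2)[nH]c2ccccc12)C(=O)c1cccs1` gives 6400 nM. Compound 2 `CCOC(=O)/C(=C/c1c(-c2ccccc2)[nH]c2ccccc12)C(=O)c1ccccc1` gives 12000 nM, the highest of the three numbers; its gap to compound 3 lies within the usual scatter, while its gap to compound 1 lies beyond it. Compound 4 `CCOC(=O)/C(=C/c1c(-c2ccccc2)[nH]c2ccccc12)C(=O)c1ccc([N+](=O)[O-])cc1` has not yet been measured in this assay. It differs from compound 2 in one place: nitro in place of hydrogen on an aromatic carbon. Among the compounds with values here, no measured pair shows what this change does on this core, so the data give no direction. The expected change is a 1.3-fold lower number from compound 2 to compound 4 (0.12 log units; within the scatter), no further than the scatter reaches. Compound 4 is estimated at 9000 nM, with a range from 3000 nM to 30000 nM.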

Compound 4, half-maximal effective concentration: 2400 nM
Compound 4: middle estimate off by 3.8-fold (0.57 log units), on the high side; measured number below the stated range.
By their numbers in this assay, from the lowest: compounds 1 and 4 (each within the scatter of the next); then compounds 3 and 2 (each within the scatter of the next).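

Nitro in place of hydrogen on this aromatic carbon brings a 5.0-fold lower number from compound 2 to compound 4 (0.70 log units; beyond the scatter) in this assay. Within the data shown here, this is the first single-place step on the shared core, and it shows that a change at this carbon of the benzoyl ring can move the number beyond the scatter. Nothing at hand explains the shift.

From the compounds shown here alone, whether an amine or a carboxylic acid on the same carbon would also lower the number remains open. So does whether nitro would do the same at another carbon of that ring.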